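Chlorine for Hydrogen in Two Related Cytotoxicity Series

The source may hold more compounds than are shown below. What is called first, only, known or untested is meant among the compounds shown, and "the series" means these compounds.

Three compounds have been measured in an ADME assay on HeLa cells (Homo sapiens) for cytotoxicity, read by MTT assay, with a stated time of 72 h; a higher number here means that more compound is tolerated, a lower number that less compound is tolerated:

Compound 1, `C(=C/c1ccccc1)\C=N\c1sc2c(c1-c1nc3ccccc3s1)CCC2`, gives 100 ug/mL.
Compound 2, `C(=C/c1ccccc1)\C=N\c1sc2c(c1-c1nc3ccccc3s1)CCCC2`, gives 389 ug/mL.
Compound 3, `Clc1ccc2sc(-c3c(/N=C/C=C/c4ccccc4)sc4c3CCC4)nc2c1`, gives 200 ug/mL.

Compound 1 and compound 3 differ by one change, (chloro in place of hydrogen on an aromatic carbon), and in this assay a 2.0-fold higher number from compound 1 to compound 3 (0.30 log units; within the scatter). The difference between the core of compound 1 and the core of compound 2 is not broken down here; compound 2 stands beyond the scatter from compound 1 and within the scatter of compound 3.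

Compound 4, `Clc1ccc2sc(-c3c(/N=C/C=C/c4ccccc4)sc4c3CCCC4)nc2c1`, has not been measured. It differs from compound 2 by chloro in place of hydrogen on an aromatic carbon, the same change as between compound 1 and compound 3. Because a 2.0-fold higher number from compound 1 to compound 3 (0.30 log units; within the scatter), a similar, small step is expected from compound 2, a 1.3-fold higher number from compound 2 to compound 4 (0.11 log units; within the scatter). Compound 4 is therefore estimated at 500 ug/mL, expected between 250 ug/mL and 1000 ug/mL.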

Compound 4, half-maximal cytotoxic concentration: 150 ug/mL
Estimate against measurement, compound 4: 3.3-fold (0.52 log units) above; measured number below the stated range.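

On the core of compound 2, chloro in place of hydrogen on an aromatic carbon gives a 2.6-fold lower number from compound 2 to compound 4 (0.41 log units; beyond the scatter) in this assay. Set beside the earlier step, the same change does not carry over between the two cores: the same change on two cores in this assay, a 2.0-fold higher number (0.30 log units; within the scatter) from compound 1 to compound 3 and a 2.6-fold lower number (0.41 log units; beyond the scatter) from compound 2 to compound 4, 5.2-fold (0.71 log units) apart, beyond the scatter of two such steps This shows that the step on one core did not foretell the step on the other, but it does not show why the two cores part, and two pairs set no general rule for the series.

The compounds shown carry only hydrogen or chloro at this place on the aromatic ring. As far as these compounds go, how a fluoro group, a methoxy group or an amine there would behave on either core stays open.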